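The compounds below may be only part of what the source reports. "The series", "measured", "known", "first", "only" and "open" are said of these compounds alone.

Measured so far in a functional assay on HT-29 cells (Homo sapiens) for antiproliferative activity, read by sulforhodamine B assay, with a stated time of 48 h; a higher number here means a weaker inhibitor, a lower number a stronger inhibitor:
compound 1 `CCC(=O)Nc1ccc(S(=O)(=O)Oc2ccccc2C(C)C)cc1` gives 7400 nM;
compound 2 `CCC(=O)Nc1ccc(S(=O)(=O)Oc2ccccc2I)cc1` gives 11000 nM.

Within the data shown here, compound 1 holds the lower of the two numbers in this assay, but its only neighbour is close: the step of a 1.5-fold higher number from compound 1 to compound 2 (0.17 log units; within the scatter) lies within the scatter, so the two compounds cannot be ranked against each other, and the swap on the aromatic ring is read as no effect.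

Compound 3 `CCCCCC(=O)Nc1ccc(S(=O)(=O)Oc2ccccc2C(C)C)cc1` is not yet measured. It differs from compound 1 by propyl in place of hydrogen on a saturated chain carbon, two bonds along the chain from a carbonyl carbon; the amide substituent grows from propanoyl to pentylcarbonyl while the rest of the shared core is kept.

Among the measured compounds shown here, no measured step bears on this change. For the measured compounds named here, the single step available alters the aromatic ring, not the chain on the amide, and it was itself within the scatter, so it gives no guide to size or direction here. With nothing to lean on, the expectation is a step not beyond the scatter, no change at the digits printed from compound 1 to compound 3 (within the scatter), with a wide range to either side.

Compound 3 is therefore estimated at 7400 nM in this assay, with a range from 2500 nM to 22000 nM.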

Compound 3, half-maximal inhibitory concentration: 6400 nM
For compound 3 the middle estimate is 1.2-fold (0.06 log units) above the measured one; measured number inside the range.
By their numbers in this assay, from the lowest: compounds 3, 1 and 2 (each within the scatter of the next).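

In this assay, the change of propyl in place of hydrogen on a saturated chain carbon, two bonds along the chain from a carbonyl carbon, gives the step of a 1.2-fold lower number from compound 1 to compound 3 (0.06 log units; within the scatter) and is read as no effect on this number. Among these compounds, this is the first reading at the amide chain, since the earlier step changed only the aromatic ring: growth from propanoyl to pentylcarbonyl, a gain of 3 heavy atoms, leaves compound 3 unranked against compound 1, and all three compounds remain within the scatter of their neighbours in the order printed. No accompanying measurement bears on this result, so the flat reading stays a plain observation at this single pair.

On these data alone, whether a longer chain than pentylcarbonyl, a shorter acyl group such as acetyl, or an amine or carboxylic acid carried on the chain would move the number beyond the scatter stays open. Also open, as far as these compounds go, is whether the same chain change, made on compound 2 with its iodo group, would read the same way.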